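The compounds below may be only part of what the source reports. "The series", "measured", "known", "first", "only" and "open" are said of these compounds alone.

Measured in an assay on isolated protein for inhibition of thyroid hormone receptor beta (Homo sapiens), read by fluorescence polarization; a higher number here means a weaker inhibitor, a lower number a stronger inhibitor:
compound 1, `CN(Cc1cccc(F)c1)C(=O)CNC(=O)c1ccc(S(C)(=O)=O)c([N+](=O)[O-])c1`: > 60000 nM
compound 2, `CS(=O)(=O)c1ccc(C(=O)N2CCC(C(=O)N(Cc3ccccc3)Cc3ccccc3)CC2)cc1[N+](=O)[O-]`: > 60000 nM
compound 3, `CN(CC(=O)N1CCN(c2ccc(F)cc2)CC1)C(=O)c1ccc(S(C)(=O)=O)c([N+](=O)[O-])c1`: > 60000 nM

Compound 1 stands at a limit of this assay: its value is a limit, not a number. Compound 2 likewise gives only a limit. Compound 3 likewise gives only a limit. Among the measured compounds shown here, this is the limit of > 60000 nM in this assay, at which 3 of the 3 values shown sit, so the three measured compounds cannot be ordered against one another, and no step between measured compounds that differ in one place exists in the set. Nothing in these numbers shows how far any single change moves the read-out.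

Compound 4, `CN(Cc1ccccc1)C(=O)CNC(=O)c1ccc(S(C)(=O)=O)c([N+](=O)[O-])c1`, is the next to be measured in this assay. It differs from compound 1 by hydrogen in place of fluoro on an aromatic carbon. The change removes one fluorine from the benzyl ring and leaves the shared core untouched.

With compound 1 at a limit, the step from compound 1 to compound 4 is expected to be none beyond the scatter, at most a step that the limit leaves unreadable from compound 1 to compound 4. Compound 4 is expected to come in at 80000 nM, with a range from 30000 nM to 300000 nM. Compound 4 is expected, most likely, to return only a limit again.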

Compound 4, half-maximal inhibitory concentration: 39000 nM
For compound 4 the middle estimate is 2.1-fold (0.31 log units) above the measured one, and the stated range covers the measured number.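

In this assay, among the compounds shown here, compound 4 gives 39000 nM, the first number in this set rather than a limit, so this benzyl amide now offers a measured reference point for the series. Compound 1 gives > 60000 nM, which is a limit and not a number. The change from 3-fluorobenzyl to benzyl on this aromatic carbon comes with an at least 1.5-fold lower number from compound 1 to compound 4 (0.18 log units; that floor lies within the scatter), and only that floor can be read, not the full size of the step, because the value on the fluoro side is not a number: the limit of > 60000 nM in this assay, at which 3 of the 4 values shown sit.

Still open, as far as these compounds go, is whether the fluoro group has any real effect on the read-out, and how a chloro group, a methoxy group or an amine on the same aromatic carbon would read against compound 4. Also open, from the compounds shown here alone, is what a carboxylic acid or a longer chain in place of the benzyl group would do, as compound 2 and compound 3 differ from compound 4 in more than one place and give no comparison with it.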